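Changing the amide group of compound 3

The source may hold more compounds than are shown below. What is called first, only, known or untested is meant among the compounds shown, and "the series" means these compounds.

In a physicochemical assay for solubility, read by spectrophotometry, measured as kinetic solubility, at pH 8, tested at 500 uM (on this read-out lower numbers stand for lower solubility and higher numbers for higher solubility), compound 1 `Cn1cc(NC(=O)c2ccncc2Nc2cc(-c3ccc4ccn(C)c4c3)c3nccnc3c2)cn1` gives 2 ug/mL, compound 2 `Cn1cc(CNC(=O)c2ccncc2Nc2cc(-c3ccc4ccn(C)c4c3)c3nccnc3c2)cn1` gives 127 ug/mL and compound 3 `Cn1ccc2ccc(-c3cc(Nc4cnccc4C(=O)NC4CCNC(=O)C4)cc4nccnc34)cc21` gives 242 ug/mL. Compound 3 therefore stands level with compound 2 and far from compound 1. Going by the values given here, three measured steps bear on the next change: a 64-fold higher number from compound 1 to compound 2 (1.80 log units; beyond the scatter) and a 120-fold higher number from compound 1 to compound 3 (2.08 log units; beyond the scatter) are both large, whereas a 1.9-fold higher number from compound 2 to compound 3 (0.28 log units; within the scatter) lies within the scatter. Compound 4 `CN1CC(NC(=O)c2ccncc2Nc2cc(-c3ccc4ccn(C)c4c3)c3nccnc3c2)CCC1=O` carries 1-methyl-6-oxopiperidin-3-yl in place of 2-oxopiperidin-4-yl on an amide-type nitrogen. Both large steps start from compound 1, and neither compound 3 nor compound 4 keeps its 1-methyl-1H-pyrazol-4-yl group, so the small step is the closer guide. In this assay the expected change is only a 1.2-fold lower number from compound 3 to compound 4 (0.08 log units; within the scatter), which would stay within the scatter. Compound 4 is estimated at 200 ug/mL, with an expected range of 100 ug/mL to 280 ug/mL.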

Compound 4, solubility: 253 ug/mL
Beside the measured number, compound 4's estimate is 1.3-fold (0.10 log units) below it; the measured number falls inside the stated range.
By their numbers in this assay, from the lowest: compound 1; then compounds 2, 3 and 4 (each within the scatter of the next).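

Replacing 2-oxopiperidin-4-yl, with 1 hydrogen-bond donor, by 1-methyl-6-oxopiperidin-3-yl, with 0, gives a 1.0-fold higher number from compound 3 to compound 4 (0.02 log units; within the scatter) in this assay, so that donor is not needed to hold this number. Likewise, a 2.0-fold higher number from compound 2 to compound 4 (0.30 log units; within the scatter) stays within the scatter, while a 130-fold higher number from compound 1 to compound 4 (2.10 log units; beyond the scatter) is large. Nothing measured here explains these results.

Still open, on these data alone, is how an amine or a carboxylic acid on this amide-type nitrogen would read. A longer chain carrying the 1-methyl-6-oxopiperidin-3-yl ring is also untested in the compounds shown.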